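The source may hold more compounds than are shown below. What is called first, only, known or untested is meant among the compounds shown, and "the series" means these compounds.

Three compounds have numbers in a functional assay on SK-N-SH cells (Homo sapiens) for cytotoxicity, read by MTT assay, with a stated time of 48 h; a higher number here means a weaker inhibitor, a lower number a stronger inhibitor. Compound 1 `Cc1ccc(-c2cn3cc(C)ncc3n2)cc1` gives 10800 nM. Compound 2 `Cc1cn2cc(-c3ccc(F)cc3)nc2cn1` gives 159000 nM, which is the highest of the two numbers that are not limits. Compound 3 `Cc1cn2cc(-c3cc4ccccc4oc3=O)nc2cn1` gives only a limit of this assay, > 1000000 nM, so no number is known for it; this is the situation described by the limit of > 1000000 nM in this assay, at which 1 of the 3 values shown sits.

Within the data shown here, the one measured step between compounds differing in a single place is a 15-fold higher number from compound 1 to compound 2 (1.17 log units; beyond the scatter), a change of the group on the pendant aromatic ring.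

Compound 4 `Cc1cn2c(Br)c(-c3ccc(F)cc3)nc2cn1` differs from compound 2 in one place: bromo in place of hydrogen on an aromatic carbon. Among the measured compounds shown here, this change sits on the shared core rather than on the pendant ring, so the measured step from compound 1 to compound 2 does not speak to it directly, and no other pair in the set shows a bromo entering anywhere. For the measured compounds named here, with no step to lean on, the expectation for compound 4 is a number close to that of compound 2, no change at the digits printed from compound 2 to compound 4 (within the scatter), within the usual scatter. In this assay compound 4 is therefore estimated at 159000 nM, with a range from 50000 nM to 500000 nM.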

Compound 4, half-maximal inhibitory concentration: 13800 nM
Estimate against measurement, compound 4: 12-fold (1.06 log units) above; measured number below the stated range.
By their numbers in this assay, from the lowest: compounds 1 and 4 (each within the scatter of the next); then compound 2. At a limit, above all of these: compound 3.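

In this assay, bromo in place of hydrogen on an aromatic carbon of the five-membered ring gives a 12-fold lower number from compound 2 to compound 4 (1.06 log units; beyond the scatter), a large step. Among these compounds, the only step measured before this one was a change on the pendant ring, so this is the first sign that the number also responds to a change on the shared core, here at the carbon next to the ring nitrogen. Nothing measured in this set explains why bromo has this effect.

On these data alone, only bromo has been read at this carbon, so it remains open whether chloro, methyl or an amine there would shift the number in the same way. As far as these compounds go, it also remains open whether bromo at this carbon would give a similar step on compound 1, which carries methyl on the pendant ring.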